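The compounds below may be only part of what the source reports. "The series", "measured", "known", "first", "only" and "open" are said of these compounds alone.

Measured so far, in a functional assay for inhibition, tested at 80 ug/mL; on this read-out higher numbers stand for a stronger effect at the one concentration tested and lower numbers for a weaker effect:

Compound 1, `COc1cccc(-c2cc(-c3cc(C(C)C)c(O)cc3C)[nH]c(=O)c2C#N)c1`: 43%
Compound 2, `COc1cc(-c2cc(-c3cc(C(C)C)c(O)cc3C)[nH]c(=O)c2C#N)ccc1O`: 42%
Compound 3, `COc1ccc(-c2cc(-c3cc(C(C)C)c(O)cc3C)[nH]c(=O)c2C#N)cc1OC`: 58%

Compound 3 stands highest of the three numbers. Its nearest neighbour is compound 1, and the step of a number 15 percentage points higher from compound 1 to compound 3 (beyond the scatter) lies beyond the scatter; compound 2 is furthest, and the step of a number 16 percentage points higher from compound 2 to compound 3 (beyond the scatter) is also beyond the scatter. The step of a number 1 percentage points lower from compound 1 to compound 2 (within the scatter) lies within the scatter, so compounds 1 and 2 cannot be told apart on this read-out.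

The next compound, compound 4, is `Cc1cc(O)c(C(C)C)cc1-c1cc(-c2ccc(N(C)C)cc2)c(C#N)c(=O)[nH]1`. It differs from compound 3 in one place: 4-(dimethylamino)phenyl in place of 3,4-dimethoxyphenyl on an aromatic carbon

Among the compounds with values here, no measured step swaps the whole group in this way, so none bears on it directly. The two steps that do touch this part of the molecule, a number 15 percentage points higher from compound 1 to compound 3 (beyond the scatter) and a number 16 percentage points higher from compound 2 to compound 3 (beyond the scatter), show that changing what sits on this phenyl group moves the read-out by a modest amount, and that the 3,4-dimethoxyphenyl arrangement gave the highest number seen. Taking that arrangement away is therefore expected to cost something, so a modest step downward, a number 13 percentage points lower from compound 3 to compound 4 (beyond the scatter), is estimated for compound 4, roughly back to where compounds 1 and 2 sit. For compound 4 the estimate in this assay is 45%, with a range from 25% to 65%.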

Compound 4, a percentage reported as inhibition, at one concentration (the size of the read-out at that concentration, not a potency): 66.5%
For compound 4 the middle estimate is 21.5 percentage points below the measured one, and the stated range ends below it.
By their numbers in this assay, from the lowest: compounds 2 and 1 (each within the scatter of the next); then compounds 3 and 4 (each within the scatter of the next).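

In this assay, the step from 3,4-dimethoxyphenyl to 4-(dimethylamino)phenyl (a number 8.5 percentage points higher from compound 3 to compound 4 (within the scatter)) cannot be told apart from no change, so a group with nitrogen and no oxygen on this phenyl ring can stand in for the two methoxy groups at this position on the shared core. The same group also stands clear of the two weaker rings, with 4-hydroxy-3-methoxyphenyl giving way to it in one step (a number 24.5 percentage points higher from compound 2 to compound 4 (beyond the scatter)) and 3-methoxyphenyl giving way to it in another (a number 23.5 percentage points higher from compound 1 to compound 4 (beyond the scatter)), so compounds 3 and 4 form an upper pair above compounds 1 and 2. Nothing measured here explains why these rings fall into two levels.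

The compounds shown leave open whether the nitrogen itself matters, since a plain amine, a morpholine ring or a carboxylic acid in place of the dimethylamino group would be needed to test how much this position tolerates. Going by these compounds, each number is also the size of the effect at a single concentration, so how compounds 3 and 4 would compare across a range of concentrations remains unknown.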